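This account rests on a few compounds, and the source may have more. Where it says the series, first, only, none or still open, it means among the compounds named here.

Two cores are compared here. Compound 1 `O=C1/C(=C/c2ccccc2[N+](=O)[O-])CCc2ccccc21` and compound 2 `Cc1ccccc1/C=C1\CCc2ccccc2C1=O` share one core; compound 3 `O=C1/C(=C/c2ccccc2[N+](=O)[O-])Cc2ccccc21` and compound 4 `Cc1ccccc1/C=C1\Cc2ccccc2C1=O` share another, and the difference between the two cores is not broken down here. In a functional assay on L1210 cells (Mus musculus) for inhibition (on this read-out lower numbers stand for stronger inhibition and higher numbers for weaker inhibition), compound 1 gives 10800 nM, and compound 2 gives 50200 nM. Compound 3 gives 7610 nM in this assay, a number within the scatter of that of compound 1 and well apart from that of compound 2.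

Compound 2 differs from compound 1 by one change, (methyl in place of nitro on an aromatic carbon), and this change produced a 4.6-fold higher number from compound 1 to compound 2 (0.67 log units; beyond the scatter). Compound 4 differs from compound 3 by methyl in place of nitro on an aromatic carbon, with the same surroundings in both cases, so it is the same change made on the other core.

Since compound 3 sits close to compound 1 in this assay, the step to compound 4 is expected to resemble the earlier one, that is a 4.6-fold higher number from compound 3 to compound 4 (0.66 log units; beyond the scatter), because the measured pair gave a 4.6-fold higher number from compound 1 to compound 2 (0.67 log units; beyond the scatter). Compound 4 is therefore estimated at 35000 nM, likely between 15000 nM and 80000 nM.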

Compound 4, half-maximal inhibitory concentration: 208000 nM
Compound 4: the middle estimate sits 5.9-fold (0.77 log units) below what was measured, outside the stated range (above it).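

In this assay, methyl in place of nitro on an aromatic carbon gives a 27-fold higher number from compound 3 to compound 4 (1.44 log units; beyond the scatter), so the number rises on both cores, but the size of the rise does not carry over: the same change on two cores in this assay, a 4.6-fold higher number (0.67 log units; beyond the scatter) from compound 1 to compound 2 and a 27-fold higher number (1.44 log units; beyond the scatter) from compound 3 to compound 4, 5.9-fold (0.77 log units) apart, beyond the scatter of two such steps

In this series, then, the direction of the step holds across the two cores, whereas a step measured on the core of compound 1 understates the step on the core of compound 3. These two pairs do not show why the sizes differ, and they cannot say whether the same gap would appear with any other exchange of groups on these cores.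

The compounds shown carry only nitro or methyl at this place, so it remains open how an amine or a carboxylic acid there would compare on each core. Going by these compounds, it also remains open whether such a group would show a larger step on the core of compound 3 as well.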